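This account rests on a few compounds, and the source may have more. Where it says the series, first, only, none or still open, it means among the compounds named here.

In a functional assay on MCF7 cells (Homo sapiens) for antiproliferative activity, read by MTT assay, with a stated time of 24 h (a higher number here means a weaker inhibitor, a lower number a stronger inhibitor), three amides built on the same core have been measured. Compound 1 `CCn1c(C(=O)N[C@@H](CC(=O)OC)C(=O)OC)ccc1C(CC)(CC)c1ccc(OCS(=O)(=O)c2ccccc2)c(C)c1` reaches only a limit of the assay, > 50000 nM. Compound 2 `CCn1c(C(=O)NCCO)ccc1C(CC)(CC)c1ccc(OCS(=O)(=O)c2ccccc2)c(C)c1` gives 15500 nM, and compound 3 `CCn1c(C(=O)NC2(CO)CC2)ccc1C(CC)(CC)c1ccc(OCS(=O)(=O)c2ccccc2)c(C)c1` gives 28800 nM. These last two cannot be told apart, the step between them being a 1.9-fold higher number from compound 2 to compound 3 (0.27 log units; within the scatter).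

Compound 4 `CCn1c(C(=O)N[C@H](CO)CCO)ccc1C(CC)(CC)c1ccc(OCS(=O)(=O)c2ccccc2)c(C)c1` is still unmeasured. It carries 3-hydroxy-1-(hydroxymethyl)propyl in place of 1-(hydroxymethyl)cyclopropyl on an amide-type nitrogen.

Among the compounds with values here, the closest precedent is the exchange of 2-hydroxyethyl for 1-(hydroxymethyl)cyclopropyl at this same place, which gave a 1.9-fold higher number from compound 2 to compound 3 (0.27 log units; within the scatter). The two steps away from compound 1 are less direct, since they remove 1,2-bis(methoxycarbonyl)ethyl, a group absent from compound 4 as well. They are an at least 3.2-fold lower number from compound 1 to compound 2 (0.50 log units; beyond the scatter) and an at least 1.7-fold lower number from compound 1 to compound 3 (0.23 log units; that floor lies within the scatter), and both are bounded only from one side by the limit. With only these few compounds, the evidence points to a modest effect from swapping one hydroxyl-bearing group for another on this nitrogen, so no step beyond the scatter is expected. The expected step is a 1.3-fold lower number from compound 3 to compound 4 (0.12 log units; within the scatter). The estimated value for compound 4 is 22000 nM, with an expected range of 10000 nM to 50000 nM.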

Compound 4, half-maximal inhibitory concentration: 28500 nM
The estimate for compound 4 lay 1.3-fold (0.11 log units) below the measured number; low and high end bracket the measured number.
By their numbers in this assay, from the lowest: compounds 2, 4 and 3 (each within the scatter of the next). At a limit, above all of these: compound 1.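

In this assay, putting 3-hydroxy-1-(hydroxymethyl)propyl in place of 1-(hydroxymethyl)cyclopropyl on the amide-type nitrogen takes away the three-membered ring and brings in more hydrogen-bond donors and acceptors, yet compound 3 and compound 4 cannot be told apart: a 1.0-fold lower number from compound 3 to compound 4 (0.00 log units; within the scatter). The comparison with the 2-hydroxyethyl amide gives the same picture, a 1.8-fold higher number from compound 2 to compound 4 (0.26 log units; within the scatter), so compounds 2, 3 and 4 now form a set of hydroxyl-bearing amides that this read-out does not separate, whether the group on the nitrogen carries a ring or not. The comparison with the 1,2-bis(methoxycarbonyl)ethyl amide reads an at least 1.7-fold lower number from compound 1 to compound 4 (0.24 log units; that floor lies within the scatter), and it gives only a floor, since the value at its starting end is a limit: the limit of > 50000 nM in this assay, at which 1 of the 4 values shown sits.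

From the compounds shown here alone, whether an amine or a carboxylic acid on this chain, in place of the hydroxyl groups, would move the number beyond the scatter of this set remains open. The compounds shown also leave open how the opposite stereocentre of 3-hydroxy-1-(hydroxymethyl)propyl would read, and whether a single methyl ester on the chain would behave like compound 1.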